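The source may report more compounds than this note shows. Statements on the series, on what has been measured and on what is new or still open speak of the compounds shown alone.

In an assay on HEK293 cells for displacement of a labelled ligand from 5-hydroxytryptamine receptor 7 (Homo sapiens), read by scintillation counting, with a stated time of 1 h (a lower number here means a stronger inhibitor, a higher number a weaker inhibitor), compound 2 `C[C@@H](NC(=O)CCCCCN1CCN(c2ccccc2-c2ccccc2)CC1)c1ccccc1` gives 10.5 nM, the lowest of the two numbers in hand, while compound 1 `O=C(CCCCCN1CCN(c2ccccc2-c2ccccc2)CC1)NCc1ccc(OCCO)cc1` gives 259 nM. For the measured compounds named here, the only measured step, a 25-fold lower number from compound 1 to compound 2 (1.39 log units; beyond the scatter), swaps one group for another on the amide nitrogen. Compound 3 `C[C@H](NC(=O)CCCCCN1CCN(c2ccccc2-c2ccccc2)CC1)c1ccccc1` differs from compound 2 in another way: the two compounds have the same atoms and bonds and differ only in configuration as drawn: 1 of 1 stereo elements differ; a stereocentre at a saturated chain carbon is drawn R in compound 2 and S in compound 3. Going by the values given here, no measured step bears on a change of configuration alone, so neither the size nor the direction of the step in this assay can be read from the data, and the two mirror-image forms may well differ. Compound 3 is therefore estimated at 30 nM, within 8 nM to 150 nM, with a step of a 2.9-fold higher number from compound 2 to compound 3 (0.46 log units; beyond the scatter) expected.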

Compound 3, inhibition constant: 10 nM
The estimate for compound 3 lay 3.0-fold (0.48 log units) above the measured number, within the range that was stated.
By their numbers in this assay, from the lowest: compounds 3 and 2 (each within the scatter of the next); then compound 1.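

Swapping the drawn configuration at the stereocentre of the 1-phenylethyl group gives a 1.1-fold lower number from compound 2 to compound 3 (0.02 log units; within the scatter) in this assay, so the two mirror-image forms cannot be told apart here. The large effect of 1-phenylethyl in place of 4-(2-hydroxyethoxy)benzyl therefore holds with either configuration, as a 26-fold lower number from compound 1 to compound 3 (1.41 log units; beyond the scatter) shows. This comparison isolates a single feature: the fact that compounds 2 and 3 differ only in the configuration as drawn

Still open, as far as these compounds go, is how much of that large effect comes from the methyl on the chain carbon and how much from losing the 2-hydroxyethoxy group, which a plain benzyl on the amide nitrogen would separate. Also open, from the compounds shown here alone, is whether a 1-phenylpropyl group would keep the two mirror-image forms this close.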